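Oxadiazole in Place of a Fluorinated Carbamate Group

The compounds below may be only part of what the source reports. "The series", "measured", "known", "first", "only" and "open" are said of these compounds alone.

Compound 1 `Cc1nc(S(C)(=O)=O)ccc1Oc1ncnc(OC2CCN(C(=O)OC(C)(C)CF)CC2)c1F` stands highest of the three measured compounds in a functional assay on isolated protein for inhibition of Glucose-dependent insulinotropic receptor (Rattus norvegicus), read by HTRF and cAMP accumulation (on this read-out higher numbers stand for larger maximal responses and lower numbers for smaller maximal responses), where compound 1 reaches 95%. Compound 2 `Cc1nc(S(C)(=O)=O)ccc1Oc1ncnc(OC2CCN(C(=O)SC3CC3)CC2)c1F` gives 80% in this assay, and compound 3 `Cc1nc(S(C)(=O)=O)ccc1Oc1ncnc(OC2CCN(C(=O)SC3CCC3)CC2)c1F` gives 81%. Both sit below compound 1: the step of a number 15 percentage points lower from compound 1 to compound 2 (beyond the scatter) and the step of a number 14 percentage points lower from compound 1 to compound 3 (beyond the scatter) each go beyond the scatter, while the step of a number 1 percentage points higher from compound 2 to compound 3 (within the scatter) lies within it.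

Compound 4 `Cc1nc(S(C)(=O)=O)ccc1Oc1ncnc(OC2CCN(C(=O)c3noc(C(C)C)n3)CC2)c1F` has not yet been measured. It differs from compound 1 by a group of 8 heavy atoms (5 carbon, 2 nitrogen, 1 oxygen; one five-membered aromatic ring with 3 hetero atoms) in place of a group of 6 heavy atoms (4 carbon, 1 oxygen, 1 fluorine; no ring), on a carbonyl carbon. The two measured steps that bear on this change both replaced the same group on the same carbonyl carbon, and both lowered the maximal response by a modest amount. A drop of similar size is therefore expected for compound 4, though the entering group is an aromatic ring unlike anything measured so far, so the expected step of a number 15 percentage points lower from compound 1 to compound 4 (beyond the scatter) carries a wide range. Compound 4 is estimated to give 80% in this assay, between 62% and 96%.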

Compound 4, largest response reached (reported as efficacy), in percent of the reference or control that the assay uses: 81%
Estimate against measurement, compound 4: 1 percentage points below, within the range that was stated.
By their numbers in this assay, from the lowest: compounds 2, 3 and 4 (each within the scatter of the next); then compound 1.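

At this carbonyl carbon, the step of a number 14 percentage points lower from compound 1 to compound 4 (beyond the scatter) shows that an aromatic ring, 5-isopropyl-1,2,4-oxadiazol-3-yl, also stands under the fluorinated carbamate group of compound 1 in this assay and that a sulfur link is not needed for this lower level. The step of no change at the digits printed from compound 3 to compound 4 (within the scatter) and the step of a number 1 percentage points higher from compound 2 to compound 4 (within the scatter) leave compounds 2, 3 and 4 inseparable on this read-out, even though the entering groups differ in ring and linking atom. No measurement shown explains this shared level.

As far as these compounds go, whether the fluorine of compound 1 contributes to its higher response remains open, and a plain tert-butyl carbamate on the same carbonyl carbon would address that. Also open, from the compounds shown here alone, is whether the isopropyl on the oxadiazole matters, which a methyl or a tert-butyl group there would test.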